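Moving the fluorine on the phenyl ring of compound 3

The source may hold more compounds than are shown below. What is called first, only, known or untested is meant among the compounds shown, and "the series" means these compounds.

Compound 3, `Cc1nc(N)sc1CCCN/C(N)=N/C(=O)NC(C)c1ccccc1F`, binds with 28.8 nM in an assay on membranes from Sf9 cells for displacement of a labelled ligand from histamine H2 receptor (Homo sapiens), read by scintillation counting, with a stated time of 60 min (on this read-out higher numbers stand for weaker inhibition and lower numbers for stronger inhibition), the lowest of the three numbers recorded, though only compound 2 sits clearly apart. Compound 1, `Cc1nc(N)sc1CCCN/C(N)=N/C(=O)NC(C)c1ccc(Br)cc1`, gives 30.2 nM, and the step of a 1.0-fold lower number from compound 1 to compound 3 (0.02 log units; within the scatter) is within the scatter. Compound 2, `Cc1nc(N)sc1CCCN/C(N)=N/C(=O)NC(C)c1ccc(OC(F)(F)F)cc1`, gives 126 nM, and the step of a 4.2-fold higher number from compound 1 to compound 2 (0.62 log units; beyond the scatter) shows that a larger group in that position of the ring weakens binding.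

Compound 4, `Cc1nc(N)sc1CCCN/C(N)=N/C(=O)NC(C)c1ccc(F)cc1`, has not yet been measured. The change from compound 3 is 4-fluorophenyl in place of 2-fluorophenyl on a saturated chain carbon bound to an amide-type nitrogen and a saturated chain carbon. Going by the values given here, two steps bear on it: the unchanged number from compound 1 to compound 3 shows the ring position of a halogen matters little, while the step from compound 1 to compound 2 shows the identity of the group at that position can matter. Fluorine is the smallest halogen, so the step is expected to be small, a 1.2-fold higher number from compound 3 to compound 4 (0.08 log units; within the scatter). Compound 4 is therefore expected to give about 35 nM, with a range from 15 nM to 80 nM.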

Compound 4, inhibition constant: 31.6 nM
Compound 4: middle estimate off by 1.1-fold (0.04 log units), on the high side, within the range that was stated.
By their numbers in this assay, from the lowest: compounds 3, 1 and 4 (each within the scatter of the next); then compound 2.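

In this assay, 4-fluorophenyl in place of 2-fluorophenyl gives a 1.1-fold higher number from compound 3 to compound 4 (0.04 log units; within the scatter), so among these compounds, moving the fluorine has no effect that can be told from the scatter. Fluoro in place of bromo on an aromatic carbon gives a 1.0-fold higher number from compound 1 to compound 4 (0.02 log units; within the scatter), again with no readable change, whereas fluoro in place of trifluoromethoxy gives a 4.0-fold lower number from compound 2 to compound 4 (0.60 log units; beyond the scatter), which sets the trifluoromethoxy compound apart from both the bromo and the fluoro compounds. Nothing available explains why these groups behave as they do.

On these data alone, it remains open whether the same flat response would hold for a chloro or methoxy group on the phenyl ring, or whether such groups would behave more like trifluoromethoxy. The compounds shown also leave open how an amine or a carboxylic acid on that ring would fare.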